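Swapping Phenyl for Morpholine on the Sulfonyl Group

The compounds below may be only part of what the source reports. "The series", "measured", "known", "first", "only" and "open" are said of these compounds alone.

Three compounds sharing one core were measured in a functional assay (aorta) with Rattus norvegicus as the target; on this read-out lower numbers stand for stronger inhibition and higher numbers for weaker inhibition:
Compound 1, `C=C(c1ccccc1)c1ccc2c(c1)[C@@H](/N=C(\NC#N)Nc1ccc(Cl)cc1)[C@H](O)C(C)(C)O2`, gives 10700 nM.
Compound 2, `CC(C)(C)C(=O)c1ccc2c(c1)[C@@H](/N=C(\NC#N)Nc1ccc(Cl)cc1)[C@H](O)C(C)(C)O2`, gives 5400 nM.
Compound 3, `CC1(C)Oc2ccc(S(=O)(=O)c3ccccc3)cc2[C@@H](/N=C(\NC#N)Nc2ccc(Cl)cc2)[C@@H]1O`, gives 500 nM.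

Compound 3 has the lowest number of the three, and both of its steps lie beyond the scatter: a 21-fold lower number from compound 1 to compound 3 (1.33 log units; beyond the scatter) and an 11-fold lower number from compound 2 to compound 3 (1.03 log units; beyond the scatter). By contrast, the step of a 2.0-fold lower number from compound 1 to compound 2 (0.30 log units; within the scatter) stays within the scatter. Among these three, the phenylsulfonyl group on the aromatic carbon gives the strongest inhibition seen.

Compound 4, `CC1(C)Oc2ccc(S(=O)(=O)N3CCOCC3)cc2[C@@H](/N=C(\NC#N)Nc2ccc(Cl)cc2)[C@@H]1O`, keeps that sulfonyl but changes what sits on it: morpholin-4-yl in place of phenyl on a sulfonyl sulfur. For the measured compounds named here, none of the measured steps alters the group attached to the sulfonyl sulfur; all of them compare different groups on the aromatic carbon itself. They show that this part of the molecule can move the number a great deal, but they give no direction for a change at the far end of the sulfonyl. With no direct guide, a moderate loss is thought somewhat more likely than a gain. For compound 4 the expected step is a 1.8-fold higher number from compound 3 to compound 4 (0.26 log units; within the scatter). The estimate for compound 4 in this assay is 900 nM, within a range from 250 nM to 4000 nM.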

Compound 4, half-maximal inhibitory concentration: 3100 nM
The estimate for compound 4 lay 3.4-fold (0.54 log units) below the measured number, and the stated range covers the measured number.
By their numbers in this assay, from the lowest: compound 3; then compounds 4, 2 and 1 (each within the scatter of the next, the first and the last beyond it).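

In this assay, the group at the far end of the sulfonyl clearly counts: with morpholin-4-yl in place of phenyl on the sulfonyl sulfur, there is a 6.2-fold higher number from compound 3 to compound 4 (0.79 log units; beyond the scatter). The sulfonyl alone therefore does not secure the low number of compound 3, and of the two groups shown on the sulfur, phenyl gives the stronger inhibition. Set against the earlier groups on the aromatic carbon, (morpholin-4-yl)sulfonyl gives a 1.7-fold lower number from compound 2 to compound 4 (0.24 log units; within the scatter) and a 3.5-fold lower number from compound 1 to compound 4 (0.54 log units; beyond the scatter), so it keeps only a modest edge over 1-phenylethenyl and no clear edge over (tert-butyl)carbonyl. No data here explain why the two groups on the sulfur differ.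

For the compounds shown here, only two groups on the sulfonyl sulfur can be compared, so it stays open whether the loss follows from giving up the aromatic ring or from the ring nitrogen and oxygen that morpholin-4-yl brings. Piperidin-1-yl, which has no ring oxygen, and a small open-chain amine such as dimethylamino would help separate these possibilities, while a phenyl ring carrying a fluorine or a methoxy group would test whether the number can fall further.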